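The source may report more compounds than this note shows. Statements on the series, on what has been measured and on what is new or still open speak of the compounds shown alone.

Compound 1, drawn as `CC(C)CNC(=O)[C@H](C)NC(=O)[C@@]1(Cc2ccccc2)CCN1C(=O)OCc1ccccc1`, was tested in an ADME assay on HELF cells (Homo sapiens) for cytotoxicity, with a stated time of 3 days; a higher number here means that more compound is tolerated, a lower number that less compound is tolerated. In this assay compound 1 reaches only a limit, > 100000 nM. Its configurational partner compound 3, drawn as `CC(C)CNC(=O)[C@H](C)NC(=O)[C@]1(Cc2ccccc2)CCN1C(=O)OCc1ccccc1`, likewise stops at a limit in this assay, > 100000 nM. The step that the two limits leave unreadable from compound 1 to compound 3 therefore cannot be sized, which follows from the limit of > 100000 nM in this assay, at which 2 of the 3 values shown sit, together with the fact that compounds 1 and 3 differ only in the configuration as drawn. A third compound, compound 2 with the structure `C[C@H](NC(=O)[C@]1(Cc2ccccc2)CCN1C(=O)OCc1ccc([N+](=O)[O-])cc1)C(N)=O`, gives a measured number in this assay, 100000 nM. That number sits at the same position as the two limits.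

The compound still to be measured is compound 4, drawn as `C[C@H](NC(=O)[C@@]1(Cc2ccccc2)CCN1C(=O)OCc1ccccc1)C(=O)NC(C)(C)C`. It differs from compound 1 by tert-butyl in place of isobutyl on an amide-type nitrogen. Among the measured compounds shown here, none of the measured steps touches this part of the molecule, and the only step that is available, a step that the two limits leave unreadable from compound 1 to compound 3, concerns a stereocentre and cannot be read at all. All three measured values sit at or at the edge of the limit of this assay, so nothing in the data points to a step in either direction for the change from isobutyl to tert-butyl. On that basis compound 4 is expected to show a step of a number no higher from compound 1 to compound 4 (the limit leaves the size open), that is, none beyond the scatter. Compound 4 is therefore estimated at 100000 nM, with a range from 50000 nM to 200000 nM, most likely again reported as a limit.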

Compound 4, minimum cytotoxic concentration: > 100000 nM
Compound 4: only a limit was reported; the forecaster's own chance of this, stated with the estimate: 70%; the middle value sits exactly at the limit.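

In this assay compound 4 gives > 100000 nM, which is a limit. Among the compounds shown here, compound 1 also stands only at a limit, so no step from compound 1 to compound 4 can be read, because of: the limit of > 100000 nM in this assay, at which 3 of the 4 values shown sit. The compounds shown leave open whether tert-butyl in place of isobutyl on an amide-type nitrogen changes tolerance at all.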